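Swapping Phenyl for Ethyl on the Aromatic Ring

The compounds below may be only part of what the source reports. "The series", "measured", "known", "first", "only" and "open" are said of these compounds alone.

Compound 2 `O=C(O)CCCSCCN1C(=O)OC[C@@H]1/C=C/[C@@H](O)Cc1cccc(-c2ccccc2)c1` carries a phenyl on an aromatic carbon of its side-chain ring. In an assay on CHO cells for displacement of a labelled ligand from prostaglandin E2 receptor EP1 subtype (Mus musculus), read by scintillation counting, with a stated time of 20 min (a lower number here means a stronger inhibitor, a higher number a weaker inhibitor), compound 2 gives > 10000 nM, which is a limit of the assay rather than a number. Compound 1 `O=C(O)CCCSCCN1C(=O)OC[C@@H]1/C=C/[C@@H](O)Cc1cccc(C(F)(F)F)c1`, with trifluoromethyl in that place, gives > 10000 nM in this assay, also a limit. The step that the two limits leave unreadable from compound 1 to compound 2 is therefore unreadable, both values sitting at the limit of > 10000 nM in this assay, at which 2 of the 2 values shown sit. Compound 3 `CCc1cccc(C[C@H](O)/C=C/[C@H]2COC(=O)N2CCSCCCC(=O)O)c1` differs from compound 2 by ethyl in place of phenyl on an aromatic carbon. Among the compounds with values here, no measured step shows how ethyl behaves here, so compound 3 is expected to stay near the limit, with an estimated 10000 nM between 2000 nM and 50000 nM. The expected step is a number no higher from compound 2 to compound 3 (the limit leaves the size open).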

Compound 3, inhibition constant: 2400 nM
Estimate against measurement, compound 3: 4.2-fold (0.62 log units) above; measured number inside the range.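

Alone among the three compounds shown, compound 3 gives a real number rather than a limit in this assay, so the group at this ring position can shift the reading. Ethyl in place of phenyl gives an at least 4.1-fold lower number from compound 2 to compound 3 (0.61 log units; beyond the scatter), and ethyl in place of trifluoromethyl gives an at least 4.1-fold lower number from compound 1 to compound 3 (0.61 log units; beyond the scatter). From the compounds shown here alone, the full size of both steps stays unknown, as compound 1 and compound 2 sit at a limit: the limit of > 10000 nM in this assay, at which 2 of the 3 values shown sit.

Nothing shown explains why ethyl differs from the other two groups. Going by these compounds, whether methyl, a longer carbon chain or an amine at this position would lower the number further also remains open.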